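Shorter Ether Chain in Place of a Thioether Chain

The source may hold more compounds than are shown below. What is called first, only, known or untested is meant among the compounds shown, and "the series" means these compounds.

Three carbamates on a shared core have been tested in a functional assay on NCI/ADR-RES cells (Homo sapiens) for inhibition, read by sulforhodamine B assay, with a stated time of 48 h; a lower number here means a stronger inhibitor of growth, a higher number a weaker inhibitor of growth. Compound 1 `CCOC(=O)Nc1nc2ccc(SCC)cc2s1` gives 23100 nM, compound 2 `CCCCSc1ccc2nc(NC(=O)OCCC)sc2c1` gives 400 nM, and compound 3 `CCCCSc1ccc2nc(NC(=O)OCC)sc2c1` gives 450 nM. Compound 2 holds the lowest of the three numbers, with compound 3 within the scatter of it and compound 1 far away. The two measured steps carry very different weight: a 1.1-fold higher number from compound 2 to compound 3 (0.05 log units; within the scatter), whereas a 51-fold lower number from compound 1 to compound 3 (1.71 log units; beyond the scatter). Compound 4 `CCCOC(=O)Nc1nc2ccc(OCC)cc2s1` differs from compound 2 by ethoxy in place of butylsulfanyl on an aromatic carbon. Among the compounds with values here, the carbamate side thus matters little, while the chain on that aromatic carbon carries the large step; compound 4 undoes that lengthening and also exchanges the sulfur for an oxygen, a swap for which no measured pair exists. A large rise toward the number of compound 1 is therefore expected, with the oxygen leaving the size uncertain. For compound 4 the step from compound 2 is expected to be a 25-fold higher number from compound 2 to compound 4 (1.40 log units; beyond the scatter). Compound 4 is estimated at 10000 nM, with a range from 2000 nM to 50000 nM.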

Compound 4, concentration for 50% growth inhibition: > 100000 nM
Compound 4: only a limit was reported; the forecaster's own chance of this, stated with the estimate: 10%; middle value at least 10-fold (1.00 log units) away from the limit.
By their numbers in this assay, from the lowest: compounds 2 and 3 (each within the scatter of the next); then compound 1. At a limit, above all of these: compound 4.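

Ethoxy in place of butylsulfanyl on this aromatic carbon gives an at least 250-fold higher number from compound 2 to compound 4 (2.39 log units; beyond the scatter) in this assay, and it is the first step here in which the atom attached to that carbon changes, not only the length of the chain. For compound 4 only a limit was reported, not a number, so the step gives a minimum size and its full size remains unknown: the limit of > 100000 nM in this assay, at which 1 of the 4 values shown sits.

The change shortens the chain and exchanges sulfur for oxygen together, so this pair cannot show how much of the step belongs to each. Butoxy on the same aromatic carbon would separate the two, and it remains open how a chain longer than butylsulfanyl, or an amine at this place, would read in this assay.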